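((4-Methylphenyl)sulfonyl)oxy Replaces Benzylamino: A Step Expected Flat

This account rests on a few compounds, and the source may have more. Where it says the series, first, only, none or still open, it means among the compounds named here.

Measured so far in a functional assay on HCT-116 cells (Homo sapiens) for cytotoxicity, read by MTT assay, with a stated time of 72 h; on this read-out higher numbers stand for weaker inhibition and lower numbers for stronger inhibition:
- compound 1 `O=C(NCc1ccc(F)cc1)c1nc(Br)c2cccnc2c1NCc1ccccc1`: > 20000 nM
- compound 2 `N[C@H]1CC[C@H](Nc2c(C(=O)NCc3ccc(Oc4ccccc4)cc3)nc(Br)c3cccnc23)CC1`: "not determined" (no result reported)
- compound 3 `N[C@H]1CC[C@H](Nc2c(C(=O)NC3CCCCC3)nc(Br)c3cccnc23)CC1`: > 10000 nM.

For compound 1 the result in this assay is only a limit of the assay, (the limit of > 20000 nM in this assay, at which 1 of the 3 values shown sits), and not a number. For compound 3 the result is likewise a limit, (the limit of > 10000 nM in this assay, at which 1 of the 3 values shown sits). For compound 2 no single number is reported. Going by the values given here, compound 1 therefore stands among values that are all limits or absent; no ordering among the three can be drawn, and no step between measured compounds is available.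

Compound 4 `Cc1ccc(S(=O)(=O)Oc2c(C(=O)NCc3ccc(F)cc3)nc(Br)c3cccnc23)cc1` differs from compound 1 in one place: ((4-methylphenyl)sulfonyl)oxy in place of benzylamino on an aromatic carbon. Among the compounds with values here, no measured step informs this change. Since every value shown sits at a limit, the step from compound 1 to compound 4 is expected to lie within the scatter, with no clear direction, as an at least 1.3-fold lower number from compound 1 to compound 4 (0.12 log units; that floor lies within the scatter). Compound 4 is estimated at 15000 nM in this assay, within a range of 3000 nM to 60000 nM, with a limit again being the likeliest outcome.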

Compound 4, half-maximal inhibitory concentration: > 20000 nM
Compound 4 gave a limit, no number; the forecaster's own chance of this, stated with the estimate: 65%; middle value at least 1.3-fold (0.12 log units) from the limit.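

Compound 1 and compound 4 both end at a limit rather than a number in this assay, so no step can be read between them: the limit of > 20000 nM in this assay, at which 2 of the 4 values shown sit.

The compounds shown leave open whether ((4-methylphenyl)sulfonyl)oxy in place of benzylamino changes anything, and which change to the shared core would give a number rather than a limit.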